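This account rests on a few compounds, and the source may have more. Where it says the series, first, only, none or still open, it means among the compounds named here.

Of the compounds shown here, three sharing one core have been measured so far: compound 1 `COC(=O)C1=C(C)NC(=S)NC1c1ccoc1`, compound 2 `CC1=C(C(=O)OCC(C)C)C(c2ccoc2)NC(=S)N1` and compound 3 `CC1=C(C(=O)OC(C)(C)C)C(c2ccoc2)NC(=S)N1`. In an assay on membranes from HeLa cells for displacement of a labelled ligand from adenosine receptor A3 (Homo sapiens), read by scintillation counting, with a stated time of 180 min, tested at 1 uM (a lower number here means less inhibition, a higher number more inhibition at the concentration tested (going by the name of the read-out)), compound 1 gives 3%, compound 2 gives 1% and compound 3 gives 19%, so compound 3 stands highest of the three, with a number 16 percentage points higher from compound 1 to compound 3 (beyond the scatter) and a number 18 percentage points higher from compound 2 to compound 3 (beyond the scatter), while a number 2 percentage points lower from compound 1 to compound 2 (within the scatter). Compound 4 `CC1=C(C(=O)OCc2ccccc2)C(c2ccoc2)NC(=S)N1` differs from compound 3 at the same place: benzyl in place of tert-butyl on an oxygen next to a carbonyl group. The measured steps at that place bear on it directly and were modest; nothing shows how benzyl compares, so a drop back toward the values of compound 1 and compound 2 is estimated, with a number 9 percentage points lower from compound 3 to compound 4 (within the scatter). Compound 4 is thus expected to give about 10%, in a range from -5% to 30%.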

Compound 4, a percentage reported as inhibition, at one concentration (the size of the read-out at that concentration, not a potency): 20%
Estimate against measurement, compound 4: 10 percentage points below, within the range that was stated.
By their numbers in this assay, from the lowest: compounds 2 and 1 (each within the scatter of the next); then compounds 3 and 4 (each within the scatter of the next).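

With benzyl on an oxygen next to a carbonyl group, a group carrying an aromatic ring reads level with tert-butyl (a number 1 percentage points higher from compound 3 to compound 4 (within the scatter)). Phenyl on the saturated chain carbon also stands apart from isopropyl (a number 19 percentage points higher from compound 2 to compound 4 (beyond the scatter)) and from hydrogen (a number 17 percentage points higher from compound 1 to compound 4 (beyond the scatter)), so tert-butyl is not the only group here that gives a number beyond the scatter of compound 1 and compound 2. No measurement at hand explains this. Still open, going by these compounds, is how a longer chain ending in phenyl would read, or a benzyl group whose ring carries an amine or a carboxylic acid.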